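The source may report more compounds than this note shows. Statements on the series, on what has been measured and on what is new or still open speak of the compounds shown alone.

Compounds measured in an in vitro ADME assay on microsomes from liver (Homo sapiens) for metabolic stability; a higher number here means faster removal of the compound, a lower number slower removal:

compound 1 `COc1ccc(-c2cccnc2)c2cc(C(=O)Nc3ccncc3)oc12`, 57 mL/min/kg
compound 2 `COc1ccc(-c2cccnc2)c2cc(C(=O)Nc3ccc(Cn4ccnc4)cc3)oc12`, 53 mL/min/kg
compound 3 `COc1ccc(-c2ccncc2)c2cc(C(=O)Nc3ccncc3)oc12`, 32.8 mL/min/kg

Compound 1 and compound 3 share one core and differ in one place: pyridin-4-yl in place of pyridin-3-yl on an aromatic carbon. That exchange gave a 1.7-fold lower number from compound 1 to compound 3 (0.24 log units; within the scatter) in this assay. Compound 2 carries a different core; the difference between compound 1 and compound 2 is not broken down here. Compound 2 and compound 1 give numbers that lie within the scatter of each other in this assay.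

Compound 4 `COc1ccc(-c2ccncc2)c2cc(C(=O)Nc3ccc(Cn4ccnc4)cc3)oc12` has not yet been measured. It differs from compound 2 by the same change: pyridin-4-yl in place of pyridin-3-yl on an aromatic carbon. Because the same change in compound 1 gave a 1.7-fold lower number from compound 1 to compound 3 (0.24 log units; within the scatter), a step of similar size is expected, so that compound 4 is estimated to move by a 1.6-fold lower number from compound 2 to compound 4 (0.21 log units; within the scatter) in this assay. Compound 4 is therefore expected to give about 33 mL/min/kg in this assay, plausibly between 20 mL/min/kg and 55 mL/min/kg.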

Compound 4, clearance: 40.7 mL/min/kg
The estimate for compound 4 lay 1.2-fold (0.09 log units) below the measured number; low and high end bracket the measured number.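

In this assay, pyridin-4-yl in place of pyridin-3-yl gave a 1.3-fold lower number from compound 2 to compound 4 (0.11 log units; within the scatter), a small step on the core of compound 2. Set beside the earlier step, it points the same way and does not differ from it beyond what repeated measurements would give: the same change on two cores in this assay, a 1.7-fold lower number (0.24 log units; within the scatter) from compound 1 to compound 3 and a 1.3-fold lower number (0.11 log units; within the scatter) from compound 2 to compound 4, 1.3-fold (0.13 log units) apart, within the scatter of two such steps. The change therefore carried across these two cores without a detectable difference, but each step lies within the scatter on its own, so the pair does not establish a real effect of the exchange, and it says nothing about other cores.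

The compounds shown leave open how the number responds when a phenyl group replaces the pyridine ring on that aromatic carbon. They also leave open what an amine or a carboxylic acid would do in place of the methoxy group.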